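A few compounds are considered here, and "the series" means these few. Any claim that something is new, unique, unknown or untested is made for them only; others in the source may bear on it.

Compound 1 `CO[C@H](c1ccccc1)[C@@H](O)[C@@H]1CC=CC(=O)O1` gives in a functional assay on A549 cells (Homo sapiens) for cytotoxicity, read by MTT assay, with a stated time of 72 h (on this read-out higher numbers stand for weaker inhibition and lower numbers for stronger inhibition), only an assay limit, > 10000 nM.
Compound 2 `CO[C@@H](c1ccccc1)[C@H](O)[C@@H]1CC=CC(=O)O1` gives in this assay likewise only a limit, > 10000 nM.
Compound 3 `O=C1C=CC(O)[C@H](/C=C/c2ccccc2)O1` gives in this assay 7900 nM.

Compound 2 thus stands at a limit, not a number, in this assay. Compound 4 `O=C1C=CC[C@@H]([C@@H](O)[C@@H](O)c2ccccc2)O1` differs from compound 2 by hydrogen in place of methyl on an oxygen on a saturated carbon. Within the data shown here, the only measured step on this scaffold is a step that the two limits leave unreadable from compound 1 to compound 2, unreadable for size because of the limit of > 10000 nM in this assay, at which 2 of the 3 values shown sit. Among the measured compounds shown here, no measured step touches the methoxy to hydroxy change itself. Nothing here points to a move beyond the scatter in either direction, so compound 4 is expected to remain near the limit. The estimated step that the limit leaves unreadable from compound 2 to compound 4 is expected to be small. Compound 4 is estimated at 12000 nM, within a range from 4000 nM to 40000 nM.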

Compound 4, half-maximal inhibitory concentration: > 10000 nM
Compound 4: only a limit was reported; the forecaster's own chance of this, stated with the estimate: 70%; the middle value is on the limit's open side.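

In this assay, among these compounds, compound 2 and compound 4 each give only a limit, not a number, so no step between them can be read. Going by these compounds, whether the methoxy to hydroxy change shifts cytotoxicity at all, and in which direction, stays open.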